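Carbamoylamino linker reinstated on the 4-hydroxyphenyl urea

A few compounds are considered here, and "the series" means these few. Any claim that something is new, unique, unknown or untested is made for them only; others in the source may bear on it.

Series of three measured ureas sharing one core. Compound 1 `COc1cc(NC(C)CCCNC(=O)NNC(=O)Nc2cccc(F)c2)c2ncccc2c1` gives 50000 nM in a functional assay on NCI-H460 cells (Homo sapiens) for inhibition, read by MTT assay, with a stated time of 72 h; on this read-out lower numbers stand for stronger inhibition and higher numbers for weaker inhibition. Compound 2 `COc1cc(NC(C)CCCNC(=O)Nc2ccc(C(F)(F)F)cc2)c2ncccc2c1` gives 24000 nM. Compound 3 `COc1cc(NC(C)CCCNC(=O)Nc2ccc(O)cc2)c2ncccc2c1` gives 34000 nM. Compound 3 stands second highest of the three numbers; its nearest neighbour is compound 2 and its furthest compound 1, and both gaps are within the scatter, so no order among them is claimed. Among the compounds with values here, the only step beyond the scatter is a 2.1-fold lower number from compound 1 to compound 2 (0.32 log units; beyond the scatter); a 1.5-fold lower number from compound 1 to compound 3 (0.17 log units; within the scatter) and a 1.4-fold higher number from compound 2 to compound 3 (0.15 log units; within the scatter) are within it.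

Compound 4 `COc1cc(NC(C)CCCNC(=O)NNC(=O)Nc2ccc(O)cc2)c2ncccc2c1` differs from compound 3 by ((4-hydroxyphenyl)carbamoyl)amino in place of 4-hydroxyphenyl on an amide-type nitrogen. Within the data shown here, this is the reverse of the step from compound 1 to compound 3, where the carbamoylamino unit left and a directly attached aryl entered; that step and the one from compound 1 to compound 2 both gave lower numbers, one beyond and one within the scatter. Putting the unit back is therefore expected to move the number upward by a small amount, a 1.5-fold higher number from compound 3 to compound 4 (0.17 log units; within the scatter), possibly within the scatter. The estimate for compound 4 is 50000 nM, with a range from 25000 nM to 100000 nM; a reading at the upper edge may come back only as a limit.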

Compound 4, half-maximal inhibitory concentration: > 100000 nM
Compound 4: no number, only a limit; the forecaster's own chance of this, stated with the estimate: 30%; middle value at least 2.0-fold (0.30 log units) from the limit.
By their numbers in this assay, from the lowest: compounds 2, 3 and 1 (each within the scatter of the next, the first and the last beyond it). At a limit, above all of these: compound 4.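

Compound 4 reaches a limit of the read-out rather than a number in this assay: the limit of > 100000 nM in this assay, at which 1 of the 4 values shown sits. With 4-hydroxyphenyl held constant, the step on the amide-type nitrogen gives a clear result for the carbamoylamino unit, an at least 2.9-fold higher number from compound 3 to compound 4 (0.46 log units; beyond the scatter), whereas the earlier removal of that unit from compound 1 to give compound 3 stayed within the scatter; the comparison with the directly attached 4-(trifluoromethyl)phenyl points the same way, an at least 4.1-fold higher number from compound 2 to compound 4 (0.61 log units; beyond the scatter). Within the carbamoylamino pair, the exchange of 3-fluorophenyl for 4-hydroxyphenyl gives an at least 2.0-fold higher number from compound 1 to compound 4 (0.30 log units; that floor lies within the scatter), so this step does not establish a difference between the two aryl groups.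

On these data alone, the true size of all three steps remains open, since compound 4 carries only a limit. Also open, as far as these compounds go, is whether an amine or a carboxylic acid in place of the hydroxy on the aromatic carbon, or a longer chain between the shared core and the urea, would change the reading of the carbamoylamino compounds in this assay.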